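The source may report more compounds than this note shows. Statements on the series, on what has been measured and on what is new or still open speak of the compounds shown alone.

In a functional assay on UACC-62 cells (Homo sapiens) for cytotoxicity, read by sulforhodamine B assay (a higher number here means a weaker inhibitor of growth, a lower number a stronger inhibitor of growth), compound 1 (`CC1=CC[C@@H]([C@@](C)(O)CCCC(C)(C)NC=S)CC1`) gives 42500 nM and compound 2 (`CC1=CC[C@@H]([C@@](C)(O)CCCC(C)(C)NC(=S)N/N=C\c2ccc(C)cc2)CC1`) gives 39000 nM. Compound 3 (`CC1=CC[C@@H]([C@@](C)(O)CCCC(C)(C)NC(=S)N/N=C\c2ccc(N(C)C)cc2)CC1`) gives only a limit, > 100000 nM, so it has no exact place on the scale. Compound 4 (`CC1=CC[C@@H]([C@@](C)(O)CCCC(C)(C)NC(=S)N/N=C\c2ccc(Cl)cc2)CC1`) differs from it in one group: chloro in place of dimethylamino on an aromatic carbon. Within the data shown here, the one measured step that bears on this change is an at least 2.5-fold higher number from compound 2 to compound 3 (0.40 log units; beyond the scatter), with dimethylamino in place of methyl on an aromatic carbon. Removing the dimethylamino group should therefore undo that step, and the expected change is an at least 2.6-fold lower number from compound 3 to compound 4 (0.42 log units; beyond the scatter), towards a lower number in this assay. Close to compound 2, the estimate for compound 4 is 38000 nM, with an expected range of 17000 nM to 85000 nM.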

Compound 4, concentration for total growth inhibition: 13800 nM
Beside the measured number, compound 4's estimate is 2.8-fold (0.44 log units) above it; measured number below the stated range.
By their numbers in this assay, from the lowest: compound 4; then compounds 2 and 1 (each within the scatter of the next). At a limit, above all of these: compound 3.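

In this assay, this place on the aromatic ring can move the number down as well as up: chloro in place of methyl gives a 2.8-fold lower number from compound 2 to compound 4 (0.45 log units; beyond the scatter). Chloro in place of dimethylamino gives an at least 7.2-fold lower number from compound 3 to compound 4 (0.86 log units; beyond the scatter), a larger span among these groups than the earlier step alone showed. The size of that span is only bounded, as compound 3 stands at a limit and not at a number: the limit of > 100000 nM in this assay, at which 1 of the 4 values shown sits.

The compounds shown leave open whether fluoro, bromo or nitro on this carbon would follow chloro. They also give no reason for the order of the groups.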